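The source may hold more compounds than are shown below. What is called first, only, known or untested is meant among the compounds shown, and "the series" means these compounds.

Two sulfonamides have been measured in an assay on HUVEC cells for inhibition of transcription factor p65 (Homo sapiens); a higher number here means a larger maximal response, a lower number a smaller maximal response. Compound 1, `Cc1ccc2cccc(NS(=O)(=O)c3ccccc3[N+](=O)[O-])c2n1`, reaches a value that is a limit of the assay rather than a number: in this assay compound 1 gives > 90%. Compound 2, `O=[N+]([O-])c1cc(C(F)(F)F)ccc1S(=O)(=O)Nc1cccc2cccnc12`, likewise stands at a limit of the assay, for in this assay compound 2 gives > 90%. Going by the values given here, both values sit at the limit of > 90% in this assay, at which 2 of the 2 values shown sit, so no step between measured compounds can be drawn and no order of the two can be read from the numbers. Compound 3, `Cc1ccc2cccc(NS(=O)(=O)c3ccc(C(F)(F)F)cc3[N+](=O)[O-])c2n1`, has not yet been measured in this assay. It differs from compound 2 in one place: methyl in place of hydrogen on an aromatic carbon. Compound 1 carries the methyl and compound 2 lacks it, yet both sit at the limit, so no change beyond the usual scatter is expected from this step. The expected step is a step that the limit leaves unreadable from compound 2 to compound 3. For compound 3 in this assay the estimate is 95%, with a range from 85% to 100%.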

Compound 3, largest response reached (reported as efficacy), in percent of the reference or control that the assay uses: > 90%
Compound 3: only a limit was reported; the forecaster's own chance of this, stated with the estimate: 80%; the middle value does not contradict the limit.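

Compound 3, like compound 1 and compound 2, stands at a limit of this assay rather than at a number, so no new step can be read for compound 3 from either of them: the limit of > 90% in this assay, at which 3 of the 3 values shown sit. The compounds shown leave open whether methyl or trifluoromethyl in place of hydrogen on an aromatic carbon changes the maximal response at all.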